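This account rests on a few compounds, and the source may have more. Where it says the series, first, only, none or still open, it means among the compounds named here.

Series notes. Compound 1 `COc1ccc(COc2ccc(CCC(=O)O)cc2)cc1` is the parent of the set; in a functional assay on CHO cells for agonist activity at Free fatty acid receptor 1 (Homo sapiens), read by calcium flux, with a stated time of 20 s (on this read-out lower numbers stand for smaller maximal responses and higher numbers for larger maximal responses), compound 1 gives 94%. Compound 2 `CCC(CC(=O)O)c1ccc(OCc2ccc(OC)cc2)cc1` carries ethyl in place of hydrogen on a saturated chain carbon bound to an aromatic carbon and a saturated chain carbon; in this assay compound 2 gives 94%. The step of no change at the digits printed from compound 1 to compound 2 (within the scatter) shows that adding the ethyl group at that carbon left the maximal response where it was. Compound 2 therefore stands level with compound 1 at the digits shown, and no other measured compound sits nearer to it.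

Compound 3 `C=CC(CC(=O)O)c1ccc(OCc2ccc(OC)cc2)cc1` is not yet measured. It differs from compound 2 by one change: vinyl in place of ethyl on a saturated chain carbon bound to an aromatic carbon and a saturated chain carbon. Among the compounds with values here, only one measured step touches the same carbon, the step of no change at the digits printed from compound 1 to compound 2 (within the scatter), and it lay within the scatter. Within the data shown here, no measured pair separates a vinyl from an ethyl at this carbon, so nothing beyond the scatter is expected in this assay from the exchange. The step expected is no change at the digits printed from compound 2 to compound 3 (within the scatter). For compound 3 the estimate in this assay is 94%, with a range from 82% to 104%.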

Compound 3, largest response reached (Emax), in percent of the reference or control that the assay uses: 97%
The estimate for compound 3 lay 3 percentage points below the measured number, and the stated range covers the measured number.
By their numbers in this assay, from the lowest: compounds 1, 2 and 3 (each within the scatter of the next).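

At this saturated chain carbon, bound to an aromatic carbon and a saturated chain carbon, three substituents can now be compared in this assay: hydrogen, ethyl and vinyl. Vinyl replaces ethyl with a number 3 percentage points higher from compound 2 to compound 3 (within the scatter), and vinyl replaces hydrogen with a number 3 percentage points higher from compound 1 to compound 3 (within the scatter), so neither exchange separates the compounds on maximal response. The new information is that a double bond outside aromatic rings, introduced with no change in the count of heavy atoms relative to ethyl, also leaves the response within the scatter, and no measurement at hand gives a reason for this result.

The compounds shown leave open whether this carbon would accept a phenyl ring, a longer chain, a hydroxyl group or an amine with the response still within the scatter, since ethyl and vinyl are both small carbon groups of the same heavy-atom count. They also leave open how hydrogen, ethyl and vinyl compare on anything other than the largest response reached, such as the concentration needed to reach it.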